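Methyl to fluoro on the pendant aryl ring of a quinazolinone series

The source may hold more compounds than are shown below. What is called first, only, known or untested is meant among the compounds shown, and "the series" means these compounds.

Compound 1 `Cc1cccc(-c2nc3cc(C)ccc3c(=O)[nH]2)c1` is the reference point of this pair. In an assay on isolated protein for inhibition of DNA topoisomerase 1 (Homo sapiens), with a stated time of 30 min, tested at 20 uM (on this read-out higher numbers stand for a stronger effect at the one concentration tested and lower numbers for a weaker effect), compound 1 gives 56.3%, the higher of the two measured numbers. Compound 2 `Cc1ccc2nc(-c3cccc(F)c3)[nH]c(=O)c2c1` carries a fluoro on the pendant ring and its methyl in another position on the shared core; in this assay compound 2 gives 0.2%, a gap to compound 1 well beyond the scatter. For the measured compounds named here, no pair of measured compounds differs in a single place, so no single-change step has been measured.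

Compound 3 `Cc1ccc2c(=O)[nH]c(-c3cccc(F)c3)nc2c1` differs from compound 1 by fluoro in place of methyl on an aromatic carbon. Since compound 2, which also carries a fluoro in place of methyl there, gives 0.2%, a downward step is expected, though compound 2 also differs in where the core methyl sits, so the drop is unlikely to be as large. The step expected from compound 1 to compound 3 is a number 26.3 percentage points lower from compound 1 to compound 3 (beyond the scatter). Compound 3 is estimated at 30%, with a range of 3% to 60%.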

Compound 3, a percentage reported as inhibition, at one concentration (the size of the read-out at that concentration, not a potency): 4.3%
Beside the measured number, compound 3's estimate is 25.7 percentage points above it; low and high end bracket the measured number.
By their numbers in this assay, from the lowest: compounds 2 and 3 (each within the scatter of the next); then compound 1.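

In this assay, for the compounds shown here, fluoro in place of methyl on an aromatic carbon of a six-membered aromatic ring of carbon only is a number 52 percentage points lower from compound 1 to compound 3 (beyond the scatter) and gives the first single-change step, showing that the read-out at this position is highly sensitive to this exchange. With fluoro on that ring, compound 3 at 4.3% and compound 2 at 0.2% lie within the scatter of each other, so the two core methyl locations do not separate this pair. Nothing measured at hand bears on the cause of the step.

A chloro, a methoxy or an amine at this place would help show how narrowly the read-out depends on methyl. Going by these compounds, whether methyl on that ring holds up with the core methyl located as in compound 2 remains open.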